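This account rests on a few compounds, and the source may have more. Where it says the series, first, only, none or still open, it means among the compounds named here.

Compound 1 `C#CCn1cc(C(=O)NC(CC(=O)NC2CCCCC2)c2ccccc2)c(=O)c2cc(F)c(Cl)nc21`: > 10000 nM
Compound 2 `C#CCn1cc(C(=O)NC(CC(=O)Nc2ccccc2)c2ccccc2)c(=O)c2cccnc21`: > 10000 nM

In a functional assay on SW-620 cells (Homo sapiens) for cytotoxicity, read by MTT assay, with a stated time of 72 h (on this read-out higher numbers stand for weaker inhibition and lower numbers for stronger inhibition), compound 1 gives > 10000 nM, which is a limit of the assay rather than a number. Compound 2 gives > 10000 nM in this assay; this value too is a limit. Among the compounds with values here, compound 1 therefore stands at the limit of > 10000 nM in this assay, at which 2 of the 2 values shown sit, so no measured step between it and any other compound can be drawn.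

Compound 3 `C#CCn1cc(C(=O)NC(CC(=O)NC2CCCC2)c2ccccc2)c(=O)c2cc(F)c(Cl)nc21` differs from compound 1 by one change, cyclopentyl in place of cyclohexyl on an amide-type nitrogen. Within the data shown here, with no step between measured compounds in hand, the size of this change in this assay cannot be read from the data. Compound 3 is expected to show 15000 nM, with a range from 5000 nM to 50000 nM, most likely again reported only as a limit. The step that the limit leaves unreadable from compound 1 to compound 3 is thus estimated to be none beyond the usual scatter.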

Compound 3, half-maximal inhibitory concentration: 2100 nM
Beside the measured number, compound 3's estimate is 7.1-fold (0.85 log units) above it; measured number outside the range, below it.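

Compound 3 is the only compound shown here with a number rather than a limit, so the substituent on this amide-type nitrogen is a place where the read-out can move. In this assay, cyclopentyl in place of cyclohexyl gives an at least 4.7-fold lower number from compound 1 to compound 3 (0.67 log units; beyond the scatter), although the change only replaces one non-aromatic carbon ring with a smaller one and neither group has hydrogen-bond donors or acceptors. The true size of this step stays open because compound 1 sits at a limit of the assay: the limit of > 10000 nM in this assay, at which 2 of the 3 values shown sit.

The compounds shown do not tell whether the trend continues with a smaller ring such as cyclobutyl or cyclopropyl, or whether an open chain such as isopropyl on the same nitrogen would serve as well. They also leave open whether the step holds without the fluorine and chlorine on the core of compound 1.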